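The compounds below may be only part of what the source reports. "The series", "measured", "known", "first", "only" and "open" are said of these compounds alone.

Compound 2, with the structure `COc1ccc(C2=NN(C(=O)c3ccc(Cl)nc3)C(c3ccc(OCc4ccccc4)cc3)C2)cc1`, is tested in a functional assay on WM 266-4 cells (Homo sapiens) for antiproliferative activity, read by MTT assay, with a stated time of 24 h (on this read-out higher numbers stand for weaker inhibition of growth and lower numbers for stronger inhibition of growth), where compound 2 gives 10600 nM. This is the highest of the three numbers measured here, though the gaps to the other two both lie within the scatter. Compound 1, built as `COc1ccc(C2=NN(C(=O)c3ccc(Cl)nc3)C(c3ccc(Br)cc3)C2)cc1`, gives 7130 nM, and the step of a 1.5-fold higher number from compound 1 to compound 2 (0.17 log units; within the scatter) comes from a benzyloxy in place of bromo on an aromatic carbon. Compound 3, built as `COc1ccc(C2=NN(C(=O)c3ccc(C)nc3Cl)C(c3ccc(OCc4ccccc4)cc3)C2)cc1`, gives 10500 nM, and the step of a 1.0-fold lower number from compound 2 to compound 3 (0.00 log units; within the scatter) comes from a 2-chloro-6-methylpyridin-3-yl in place of 6-chloropyridin-3-yl on a carbonyl carbon.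

Compound 4 has the structure `O=C(c1ccc(Cl)nc1)N1N=C(c2ccc(Cl)cc2)CC1c1ccc(OCc2ccccc2)cc1`. It differs from compound 2 by chloro in place of methoxy on an aromatic carbon; cut one bond further out, the change reads 4-methoxyphenyl to 4-chlorophenyl. Neither measured step touches the ring that carries the methoxy group, so there is no direct guide for this change. Both measured changes elsewhere on the shared core left the number within the scatter, and with no measured change on this ring the estimate assumes the same. The expected step is therefore a 1.1-fold lower number from compound 2 to compound 4 (0.03 log units; within the scatter), nothing beyond the scatter. Compound 4 is expected to give 10000 nM in this assay, with a range from 4000 nM to 25000 nM.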

Compound 4, concentration for 50% growth inhibition: 13200 nM
For compound 4 the middle estimate is 1.3-fold (0.12 log units) below the measured one, within the range that was stated.
By their numbers in this assay, from the lowest: compounds 1, 3, 2 and 4 (each within the scatter of the next).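

Putting chloro in place of methoxy, on the aromatic carbon para to a large group, gives a 1.2-fold higher number from compound 2 to compound 4 (0.10 log units; within the scatter) in this assay. Among these compounds, this is the first measured change on this ring, which neither earlier step touched, and it shows that the ring can take a different substituent here with no shift that can be told from the scatter, even though the methoxy group that leaves has two heavy atoms and one hydrogen-bond acceptor, while the chloro that enters has one heavy atom and no acceptor. No independent measurement is available that could explain this result, so the step stands as an observation only.

Going by these compounds, a single swap between two groups cannot show how far this position tolerates change, so it remains open whether an amine or a carboxylic acid in place of the methoxy would move the number beyond the scatter. On these data alone, it is also open whether the swap from methoxy to chloro would give a similar step if bromo, rather than benzyloxy, sat on the other aromatic ring of the shared core.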